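Cytotoxicity notes: benzyloxy ring swap in anilinopyrimidine series

The source may hold more compounds than are shown below. What is called first, only, known or untested is meant among the compounds shown, and "the series" means these compounds.

Compound 1 `N#Cc1ccc(Nc2nccc(OCc3ccccc3Cl)n2)cc1` is the reference point of this set. Within the data shown here, in an ADME assay on MT4 cells (Homo sapiens) for cytotoxicity, read by MTT assay, with a stated time of 5 days (on this read-out lower numbers stand for higher toxicity in this test and higher numbers for lower toxicity in this test), compound 1 gives 146000 nM, the highest of the two numbers measured so far. Among the measured compounds shown here, its only neighbour is compound 2 `N#Cc1ccc(Nc2nccc(OCc3ccccc3Br)n2)cc1`, which in this assay gives 130000 nM; the step of a 1.1-fold lower number from compound 1 to compound 2 (0.05 log units; within the scatter) is within the scatter, so the two compounds cannot be ordered on this read-out.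

Compound 3 `COc1cccc(COc2ccnc(Nc3ccc(C#N)cc3)n2)c1` has not yet been measured in this assay. It differs from compound 1 as follows: 3-methoxyphenyl in place of 2-chlorophenyl on a saturated chain carbon bound to an oxygen on an aromatic ring. For the measured compounds named here, no measured step covers this change. Going by the values given here, the one step available, a 1.1-fold lower number from compound 1 to compound 2 (0.05 log units; within the scatter), only shows that exchanging one halogen for another on that ring left the number where it was; it says nothing about a methoxy ring in place of a halogen ring. Among the compounds with values here, with no step bearing on the change, the working expectation for compound 3 is a number close to that of compound 1, with a wider range to allow for the untested change. Compound 3 is therefore estimated at 140000 nM, between 70000 nM and 280000 nM. The expected step is a 1.0-fold lower number from compound 1 to compound 3 (0.02 log units; within the scatter), none beyond the scatter.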

Compound 3, half-maximal cytotoxic concentration: 118000 nM
The estimate for compound 3 lay 1.2-fold (0.07 log units) above the measured number; the range from low to high includes it.
By their numbers in this assay, from the lowest: compounds 3, 2 and 1 (each within the scatter of the next).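

In this assay, the earlier pair covered only an exchange of one halogen for another, whereas this result extends the comparison to a ring without halogen, on a saturated chain carbon bound to an oxygen on an aromatic ring: the change gives a 1.2-fold lower number from compound 1 to compound 3 (0.09 log units; within the scatter) and a 1.1-fold lower number from compound 2 to compound 3 (0.04 log units; within the scatter). Across these three compounds, neither a halogen on the ring nor the absence of a hydrogen-bond acceptor in the group is needed to keep the number within the scatter, and 3-methoxyphenyl, with its added hydrogen-bond acceptor, cannot be ordered against 2-chlorophenyl or 2-bromophenyl on this read-out. No measured evidence is available to account for this result.

The compounds shown leave open how much the methoxy group and its place on the ring each contribute, as the step changes both together. They also leave open whether a carboxylic acid or an amine on the ring, or a longer chain in place of the saturated chain carbon, would give a step beyond the scatter in this assay.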